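The source may report more compounds than this note shows. Statements on the series, on what has been measured and on what is new or still open speak of the compounds shown alone.

Of the compounds shown here, three sharing one core have been measured in an in vivo ADME assay on the whole organism (plasma, strain Sprague-Dawley) for pharmacokinetics, with Rattus norvegicus as the target, given by the intravenous route; a lower number here means slower removal, a higher number faster removal of the compound. Compound 1 `O=C(C[C@H]1CC[C@]2(CC1)OO[C@]1(O2)C2CC3CC(C2)CC1C3)N1CCNCC1`, with piperazin-1-yl on the carbonyl carbon, gives 168 mL/min/kg. Compound 2 `O=C(C[C@H]1CC[C@]2(CC1)OO[C@]1(O2)C2CC3CC(C2)CC1C3)N1CCC(O)CC1`, with 4-hydroxypiperidin-1-yl there, gives 37 mL/min/kg. Compound 3 `NC1CCN(C(=O)C[C@H]2CC[C@]3(CC2)OO[C@]2(O3)C3CC4CC(C3)CC2C4)CC1`, with 4-aminopiperidin-1-yl, gives 157 mL/min/kg. This puts compound 3 level with compound 1: the step of a 1.1-fold lower number from compound 1 to compound 3 (0.03 log units; within the scatter) lies within the scatter. The step of a 4.5-fold lower number from compound 1 to compound 2 (0.66 log units; beyond the scatter) and the step of a 4.2-fold higher number from compound 2 to compound 3 (0.63 log units; beyond the scatter) both lie beyond it, leaving compound 2 alone at the low end.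

Compound 4 `CC(C)(N)CNC(=O)CC[C@H]1CC[C@]2(CC1)OO[C@]1(O2)C2CC3CC(C2)CC1C3` has not yet been measured. Its difference from compound 3 is ((2-amino-2-methylpropyl)carbamoyl)methyl in place of (4-aminopiperidin-1-yl)carbonyl on a saturated chain carbon bound to a saturated ring carbon. In words, ((2-amino-2-methylpropyl)carbamoyl)methyl stands in place of (4-aminopiperidin-1-yl)carbonyl, on a saturated chain carbon bound to a saturated ring carbon. Among the measured compounds shown here, no measured step tests this exchange of a ring for an open chain, so the guidance is indirect. For the measured compounds named here, compound 4 keeps an amino group and has no hydroxy group, and the one measured exchange of those two groups is the step of a 4.2-fold higher number from compound 2 to compound 3 (0.63 log units; beyond the scatter). That points towards compound 3 rather than compound 2, with some allowance for the untested chain. The expected step is small and within the scatter, a 1.4-fold lower number from compound 3 to compound 4 (0.14 log units; within the scatter). Compound 4 is estimated at 115 mL/min/kg, with an expected range of 50 mL/min/kg to 210 mL/min/kg.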

Compound 4, clearance: 134 mL/min/kg
Compound 4: middle estimate off by 1.2-fold (0.07 log units), on the low side; low and high end bracket the measured number.
By their numbers in this assay, from the lowest: compound 2; then compounds 4, 3 and 1 (each within the scatter of the next).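

In this assay, the ring of compound 3 can give way to an open chain without a step beyond the scatter (a 1.2-fold lower number from compound 3 to compound 4 (0.07 log units; within the scatter)), even though the entering group has no ring and has 2 hydrogen-bond donors in place of 1, and the same holds against the piperazin-1-yl group (a 1.3-fold lower number from compound 1 to compound 4 (0.10 log units; within the scatter)). At this saturated chain carbon, compound 1, compound 3 and compound 4, which all carry an amine, now stand level, while compound 2, the only one with a hydroxy group, stays apart (a 3.6-fold higher number from compound 2 to compound 4 (0.56 log units; beyond the scatter)); among these four compounds none goes against that split, and the earlier compounds had shown it only for groups built on a ring. No evidence is available to explain why the numbers fall this way.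

The compounds shown leave open whether the split follows the amine and the hydroxy group themselves, which a 2-hydroxy-2-methylpropyl chain in place of the 2-amino-2-methylpropyl chain of compound 4 would test directly. From the compounds shown here alone, how a carboxylic acid, a tertiary amine or a longer chain at this place would read in this assay also remains open.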